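This account rests on a few compounds, and the source may have more. Where it says the series, first, only, none or still open, it means among the compounds named here.

Measured so far:
- compound 1, `Cc1c(C(=O)N/N=C\c2ccccc2O)oc2cccc(O)c12`: 8350 nM
- compound 2, `Cc1c(C(=O)N/N=C\c2cc(O)ccc2O)oc2cccc(O)c12`: 95500 nM

Both compounds share one core and differ only in the aryl group on the carbon with a double bond to nitrogen. In a functional assay on PC-3 cells (Homo sapiens) for inhibition (a lower number here means a stronger inhibitor, a higher number a weaker inhibitor), compound 2 gives the highest of the two numbers; its nearest neighbour is compound 1, and the step of an 11-fold higher number from compound 1 to compound 2 (1.06 log units; beyond the scatter) is the only one measured in the series. That step, hydroxy in place of hydrogen on an aromatic carbon, is large and runs towards weaker inhibition.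

Compound 3, `Cc1c(C(=O)N/N=C\c2ccccc2)oc2cccc(O)c12`, has not yet been measured. It differs from compound 2 as follows: phenyl in place of 2,5-dihydroxyphenyl on a carbon with a double bond to nitrogen. Within the data shown here, the one measured step bears on this change only in part: it covers the loss of one hydroxy, which on its own would be expected to return the number to near that of compound 1, while the loss of the second hydroxy has no measured counterpart and could move the number either way. The expected step of a 9.6-fold lower number from compound 2 to compound 3 (0.98 log units; beyond the scatter) is therefore towards a lower number, of about the size seen between compound 1 and compound 2, with wide uncertainty. For compound 3 the estimate in this assay is 10000 nM, within a range of 2000 nM to 60000 nM.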

Compound 3, half-maximal inhibitory concentration: 29200 nM
Compound 3: middle estimate off by 2.9-fold (0.47 log units), on the low side, and the stated range covers the measured number.
By their numbers in this assay, from the lowest: compound 1; then compound 3; then compound 2.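

Replacing 2,5-dihydroxyphenyl with phenyl on the carbon with a double bond to nitrogen in this assay gives a 3.3-fold lower number from compound 2 to compound 3 (0.51 log units; beyond the scatter) and so recovers only part of the loss seen with the second hydroxy. Among these compounds, removing the hydroxy from the aryl group of compound 1 gives a 3.5-fold higher number from compound 1 to compound 3 (0.54 log units; beyond the scatter) and shows for the first time that a hydroxy on this aryl group can go with a lower number as well as a higher one. The order therefore does not follow the hydroxy count: compound 3, with no hydroxy on this aryl group, lies between compound 1 with one and compound 2 with two, and compound 2 goes against any reading that more hydroxy means a lower number.

No measurement on hand accounts for this order. Still open, from the compounds shown here alone, is whether the lower number of compound 1 needs a hydroxy specifically, which a methoxy, an amine or a fluorine on the same aromatic carbon would test, and whether the higher number of compound 2 would persist with a methoxy in place of its added hydroxy.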